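Swapping One Aryl Group on Compound 2

This account rests on a few compounds, and the source may have more. Where it says the series, first, only, none or still open, it means among the compounds named here.

Measured in a functional assay on A549 cells (Homo sapiens) for cytotoxicity, read by MTT assay, with a stated time of 72 h; a higher number here means a weaker inhibitor, a lower number a stronger inhibitor:
Compound 1 `CNC(=O)c1cc(Oc2ccc(C3=NNC(c4cc(OC)c(OC)c(OC)c4)C3)cc2)ccn1`: 37100 nM
Compound 2 `CNC(=O)c1cc(Oc2ccc(C3=NNC(c4ccc([N+](=O)[O-])cc4)C3)cc2)ccn1`: 19500 nM

Compound 1 at 37100 nM and compound 2 at 19500 nM lie within the usual scatter of each other, so neither number stands apart, even though the two compounds carry different groups at the same place. Compound 3 `CNC(=O)c1cc(Oc2ccc(C3=NNC(c4ccc(Cl)c(Cl)c4)C3)cc2)ccn1` has 3,4-dichlorophenyl in place of 4-nitrophenyl on a saturated ring carbon. Among the measured compounds shown here, no measured pair differs in only one place, so the evidence is thin, and no change beyond the scatter is expected in this assay. The expected step, a 1.4-fold lower number from compound 2 to compound 3 (0.14 log units; within the scatter), is small. Compound 3 is estimated at 14000 nM, with an expected range of 5000 nM to 38000 nM.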

Compound 3, half-maximal inhibitory concentration: 10700 nM
The estimate for compound 3 lay 1.3-fold (0.12 log units) above the measured number, within the range that was stated.
By their numbers in this assay, from the lowest: compounds 3, 2 and 1 (each within the scatter of the next, the first and the last beyond it).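

Among the compounds shown here, this is the first readable step at this saturated ring carbon, and it tests one aryl group against another on an otherwise unchanged compound. In this assay, 3,4-dichlorophenyl in place of 4-nitrophenyl gives a 1.8-fold lower number from compound 2 to compound 3 (0.26 log units; within the scatter), so this exchange does not separate the two compounds. Nothing measured here bears on the reason for this result. The compounds shown carry only aryl groups at this carbon, so it remains open whether an amine, a carboxylic acid or a longer chain there would give a number beyond the scatter.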